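This account rests on a few compounds, and the source may have more. Where it says the series, first, only, none or still open, it means among the compounds named here.

Measured in a functional assay on MCF7 cells (Homo sapiens) for antiproliferative activity, read by MTT assay, with a stated time of 48 h; on this read-out higher numbers stand for weaker inhibition and lower numbers for stronger inhibition:
- compound 1 `O=[N+]([O-])c1cc(C(F)(F)F)cc([N+](=O)[O-])c1Oc1ccc(Cl)cc1/C=N\OCc1ccccc1` gives 1220 nM
- compound 2 `O=[N+]([O-])c1cc(C(F)(F)F)cc([N+](=O)[O-])c1Oc1ccc(Cl)cc1/C=N\OCc1ccccc1Cl` gives 3950 nM

Compound 1 holds the lower of the two numbers, so it is the stronger inhibitor of this pair, and the gap to compound 2 lies beyond the scatter. Compound 3 `O=[N+]([O-])c1cc(C(F)(F)F)cc([N+](=O)[O-])c1Oc1c(Cl)cc(Cl)cc1/C=N\OCc1ccccc1` keeps the core of compound 1 and changes it in one place (chloro in place of hydrogen on an aromatic carbon). A chloro replaces a hydrogen on an aromatic carbon, ortho to a large group and meta to a chloro group.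

Among the compounds with values here, only one measured step bears on this. It is the same kind of swap, made elsewhere in the molecule: a 3.2-fold higher number from compound 1 to compound 2 (0.51 log units; beyond the scatter). That modest step points towards a higher number, but a single pair at another place is thin evidence, and the new position has not been tested. A smaller step in the same direction therefore seems the fair expectation, and no change at all cannot be ruled out. The expected step is a 1.5-fold higher number from compound 1 to compound 3 (0.17 log units; within the scatter), and it is only a loose estimate. The estimate for compound 3 is 1800 nM, expected to fall between 600 nM and 5000 nM in this assay.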

Compound 3, half-maximal inhibitory concentration: 1210 nM
Estimate against measurement, compound 3: 1.5-fold (0.17 log units) above; low and high end bracket the measured number.
By their numbers in this assay, from the lowest: compounds 3 and 1 (each within the scatter of the next); then compound 2.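

In this assay, placing a chloro on this aromatic carbon, ortho to a large group and meta to a chloro group, gives a 1.0-fold lower number from compound 1 to compound 3 (0.00 log units; within the scatter), so compound 1 and compound 3 cannot be told apart and this position tolerates the extra chlorine atom on this read-out. The earlier pair could not show this: made elsewhere in the molecule, the same swap gave a 3.2-fold higher number from compound 1 to compound 2 (0.51 log units; beyond the scatter), so an identical hydrogen-to-chloro exchange has a different outcome at these two places, and its result at one place could not be carried over to the other. No measurement available here explains why the two places differ.

A chloro is the only group shown at this position, so it remains open whether a larger or quite different group there, such as a methoxy group, an amine or a carboxylic acid, would be tolerated equally well. Within the data shown here, also open is what happens when both added chloro groups, the one in compound 2 and the one in compound 3, stand in a single molecule.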